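A few compounds are considered here, and "the series" means these few. Any claim that something is new, unique, unknown or untested is made for them only; others in the source may bear on it.

Measured compounds:
compound 1, `COc1ccc(OC(=O)Nc2ccc([Se]C#N)cc2)cc1`, 41500 nM
compound 2, `C=CCOC(=O)Nc1ccc([Se]C#N)cc1`, 48600 nM

Two selenocyanate carbamates have been measured in a functional assay on HT-29 cells (Homo sapiens) for cytotoxicity, read by MTT assay, with a stated time of 72 h; on this read-out higher numbers stand for weaker inhibition of growth and lower numbers for stronger inhibition of growth. Compound 1 gives 41500 nM. Compound 2, which carries an allyl ester in place of the aryl ester, gives 48600 nM. The two numbers lie within the scatter of each other, so nothing separates compound 1 from compound 2 on this read-out; compound 1 simply holds the lower of the two figures.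

The next compound, compound 3, `N#C[Se]c1ccc(NC(=O)Oc2ccc(F)cc2)cc1`, keeps the shared core of compound 1 and changes only the substituent on the ester-side ring: fluoro in place of methoxy on an aromatic carbon. The change sits on an aromatic carbon of a six-membered aromatic ring of carbon only, para to a large group. Within the data shown here, no measured pair in this set isolates such a change, so there is no observed step to lean on. Given how close compound 1 and compound 2 stand, the step from compound 1 to compound 3 is expected to be small, a 1.1-fold higher number from compound 1 to compound 3 (0.04 log units; within the scatter), with no direction beyond the scatter favoured. Compound 3 is therefore estimated to give 45000 nM in this assay, within a range from 20000 nM to 100000 nM.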

Compound 3, concentration for total growth inhibition: 37600 nM
Beside the measured number, compound 3's estimate is 1.2-fold (0.08 log units) above it; the measured number falls inside the stated range.
By their numbers in this assay, from the lowest: compounds 3, 1 and 2 (each within the scatter of the next).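

With this step the set gains its first pair that differs in one place only: fluoro in place of methoxy on an aromatic carbon, para to a large group, gives a 1.1-fold lower number from compound 1 to compound 3 (0.04 log units; within the scatter) in this assay. At this position, then, the read-out does not separate the two substituents, even though they differ in their counts: methoxy has more heavy atoms and a hydrogen-bond acceptor, and fluoro has no hydrogen-bond acceptor. No measurement shown here speaks to what lies behind this result, so the step stands as an observation for this one pair.

The compounds shown leave open whether any substituent at this position can move the number beyond the scatter, since only methoxy and fluoro can be compared there, and an amine, a carboxylic acid or a longer chain such as butoxy on the same aromatic carbon would test that more widely. They also leave open whether fluoro in place of methoxy would give a similarly small step on another position of the ring, or with an ester side other than this aromatic one.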